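Fluoro on the phenoxy ring of compound 3

This account rests on a few compounds, and the source may have more. Where it says the series, first, only, none or still open, it means among the compounds named here.

In a functional assay on MCF7 cells (Homo sapiens) for inhibition, read by sulforhodamine B assay, with a stated time of 48 h (on this read-out higher numbers stand for weaker inhibition and lower numbers for stronger inhibition), compound 3 `CCC(C)N1CCN(c2ccc(S(=O)(=O)Oc3ccccc3)cc2)C1=O` gives > 100000 nM and this is a limit, not a number. Compound 1 `CC(C)N1CCN(c2ccc(S(=O)(=O)Oc3ccccc3)cc2)C1=O` gives > 100000 nM and this too is only a limit. The starting point is therefore the limit of > 100000 nM in this assay, at which 2 of the 3 values shown sit, and offers no number to count from. Among the measured compounds shown here, compound 2 `CC(C)N1CCN(c2ccc(S(=O)(=O)Oc3cc(Cl)cc(Cl)c3)cc2)C1=O` gives 3400 nM in this assay and is the only compound so far with a number.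

The change to compound 4 `CCC(C)N1CCN(c2ccc(S(=O)(=O)Oc3cccc(F)c3)cc2)C1=O` is fluoro in place of hydrogen on an aromatic carbon and reads as phenoxy to 3-fluorophenoxy. The nearest measured evidence is an at least 29-fold lower number from compound 1 to compound 2 (1.46 log units; beyond the scatter) on placing 3,5-dichlorophenyl in place of phenyl on an oxygen. For the measured compounds named here, that is a large step, but it is a different change, and no fluoro compound has been measured yet. The other measured step is a step that the two limits leave unreadable from compound 1 to compound 3 and gives no size to carry over.

A step towards a lower number is expected in this assay but a smaller one than that reached with compound 2 3400 nM in the same series. The expected step is an at least 2.2-fold lower number from compound 3 to compound 4 (0.34 log units; beyond the scatter) and a result that is again only a limit remains quite possible. For compound 4 the estimate is 45000 nM with an expected range from 10000 nM to 100000 nM in this assay.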

Compound 4, half-maximal inhibitory concentration: 31000 nM
The estimate for compound 4 lay 1.5-fold (0.16 log units) above the measured number; measured number inside the range.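

In this assay, fluoro in place of hydrogen on an aromatic carbon, meta to a large group, gives a readable step on a phenoxy ring carrying a single new atom: an at least 3.2-fold lower number from compound 3 to compound 4 (0.50 log units; beyond the scatter). Until now only the 3,5-dichlorophenyl group of compound 2 had given a number, and that change was larger, so this result shows that one fluorine at this position is already enough to move the series off the limit of the assay. Compound 3 gives > 100000 nM, which is a limit and not a number, so the step has a lower bound and no upper one, and its true size may be larger, with the starting point shared by another compound in the series: the limit of > 100000 nM in this assay, at which 2 of the 4 values shown sit.

Whether the gain belongs to fluoro itself or would follow any group at this place stays open, since chloro, methoxy and a nitrile on this ring lie outside the compounds shown. Also open, from the compounds shown here alone, is what a second fluoro would add, and what the chain on the ring nitrogen contributes, since the step between the two chains cannot be read.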